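Replacing the nitrile of compound 1 with methylpiperazine

This account rests on a few compounds, and the source may have more. Where it says the series, first, only, none or still open, it means among the compounds named here.

Going by the values given here, compound 1 `Cc1ccccc1-c1nc2cc(-c3nc4cc(C#N)ccc4[nH]3)ccc2[nH]1` is tested in a functional assay on RPMI 8402 cells (Homo sapiens) for cytotoxicity (a lower number here means a stronger inhibitor, a higher number a weaker inhibitor), where compound 1 gives 1200 nM, the highest of the two numbers known. Compound 2 `N#Cc1ccc2[nH]c(-c3ccc4[nH]c(-c5cccc6ccccc56)nc4c3)nc2c1` gives 650 nM in this assay, and the step of a 1.8-fold lower number from compound 1 to compound 2 (0.27 log units; within the scatter) lies within the scatter. Compound 3 `Cc1ccccc1-c1nc2cc(-c3nc4cc(N5CCN(C)CC5)ccc4[nH]3)ccc2[nH]1` differs from compound 1 by 4-methylpiperazin-1-yl in place of cyano on an aromatic carbon. Among the compounds with values here, no measured step touches this site, and the one known step concerns a different group on the shared core, so it gives no direction. Compound 3 is therefore expected near compound 1, at 1000 nM (range 250 nM to 4000 nM), a step of a 1.2-fold lower number from compound 1 to compound 3 (0.08 log units; within the scatter) estimated to stay within the scatter.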

Compound 3, half-maximal inhibitory concentration: 590 nM
Beside the measured number, compound 3's estimate is 1.7-fold (0.23 log units) above it, and the stated range covers the measured number.
By their numbers in this assay, from the lowest: compounds 3, 2 and 1 (each within the scatter of the next, the first and the last beyond it).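

In this assay, going by these compounds alone, the exchange of cyano for 4-methylpiperazin-1-yl gives a 2.0-fold lower number from compound 1 to compound 3 (0.31 log units; beyond the scatter), a first reading at this site, which the earlier step did not touch. The shared core therefore carries the larger ring here without the number rising, and the modest step goes towards a stronger inhibitor. Nothing available explains this step. The compounds shown leave open whether the ring or its second nitrogen matters, which a morpholine ring or an unsubstituted piperazine at this carbon would address. They also leave open how a simple amine or a carboxylic acid would behave there.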